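Adding one carbon to the chain of compound 3

The source may report more compounds than this note shows. Statements on the series, on what has been measured and on what is new or still open speak of the compounds shown alone.

Compound 1 `N=C(N)c1ccc(-c2nc3ccc(C(=N)N)cc3n2O)cc1`: > 210000 nM, a limit
Compound 2 `Cn1c(-c2ccc(C(=N)N)cc2)nc2cc(C(=N)N)ccc21`: > 169000 nM, a limit
Compound 3 `CCn1c(-c2ccc(C(=N)N)cc2)nc2cc(C(=N)N)ccc21`: > 207000 nM, a limit

These three compounds were tested in a toxicity assay (L6 cells) for cytotoxicity, with Rattus norvegicus as the target, read by resazurin assay, with a stated time of 70 h; a higher number here means a weaker inhibitor, a lower number a stronger inhibitor. In this assay compound 3 gives > 207000 nM, and this is a limit, not a number. The values of compound 1 and compound 2 are limits too, so no order among the three can be read.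

Compound 4 `CCCn1c(-c2ccc(C(=N)N)cc2)nc2cc(C(=N)N)ccc21` extends the chain of compound 3, ethyl to propyl. The change is methyl in place of hydrogen on a saturated chain carbon, two bonds along the chain from an aromatic nitrogen.

Among the measured compounds shown here, one measured step bears on this change, since it also places a methyl on a saturated chain carbon: a step that the two limits leave unreadable from compound 2 to compound 3. That step has no readable size, so it offers no direction and no sign of a large effect. No change beyond the usual scatter is therefore expected, and the expected move is an at least 1.0-fold lower number from compound 3 to compound 4 (0.03 log units; that floor lies within the scatter). Another limit is the most likely report for the new compound. For compound 4 the estimated value is 190000 nM, with an expected range from 70000 nM to 300000 nM.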

Compound 4, half-maximal inhibitory concentration: > 137000 nM
Compound 4: no number, only a limit (the forecaster's own chance of this, stated with the estimate: 75%); the middle value is on the limit's open side.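

In this assay compound 4 gives > 137000 nM, which is a limit and not a number. The values of compound 2 and compound 3 are limits too, and the steps from them to compound 4 cannot be read. The compounds shown leave open whether going from methyl through ethyl to propyl changes this reading at all.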